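The compounds below may be only part of what the source reports. "The series", "measured", "known", "first", "only" and "open" are said of these compounds alone.

In a functional assay on MCF7 cells (Homo sapiens), read by MTT assay, with a stated time of 48 h (a higher number here means a weaker inhibitor, a lower number a stronger inhibitor), compound 1 `CCn1c(C(=O)NCCN(C)C)ccc1C(CC)(CC)c1ccc(OCC(=O)C(C)(C)C)c(C)c1` gives 520 nM and compound 2 `CCn1c(C(=O)NCCN(C)C)ccc1C(CC)(CC)c1ccc(OCC(O)C(C)(C)C)c(C)c1` gives 660 nM, so the two stand level within the scatter. Compound 3 `CC[C@@H](C)[C@H](NC(=O)c1ccc(C(CC)(CC)c2ccc(OCC(=O)C(C)(C)C)c(C)c2)n1CC)C(=O)O` carries 1-carboxy-2-methylbutyl in place of 2-(dimethylamino)ethyl on an amide-type nitrogen. Going by the values given here, the only measured step, a 1.3-fold higher number from compound 1 to compound 2 (0.10 log units; within the scatter), concerns a different part of the molecule, and no measured pair alters this amide substituent. The data therefore give no firm direction, and the expected change is a 1.3-fold lower number from compound 1 to compound 3 (0.11 log units; within the scatter). For compound 3 the estimated value is 400 nM, with an expected range of 70 nM to 2500 nM.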

Compound 3, half-maximal inhibitory concentration: 160 nM
Compound 3: the middle estimate sits 2.5-fold (0.40 log units) above what was measured; the range from low to high includes it.
By their numbers in this assay, from the lowest: compound 3; then compounds 1 and 2 (each within the scatter of the next).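

The amide substituent, unlike the change tested earlier, moves the number in this assay: 1-carboxy-2-methylbutyl in place of 2-(dimethylamino)ethyl on the amide-type nitrogen gives a modest step beyond the scatter (a 3.3-fold lower number from compound 1 to compound 3 (0.51 log units; beyond the scatter)). No measurement shown here accounts for this step. The compounds shown leave open whether the carboxylic acid, the branched chain or the defined stereocentres carry the step. A carboxymethyl group or a methyl ester on the same nitrogen would help to separate them.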